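An Allyl Ether Aldehyde and Its Propargyl Counterpart

This account rests on a few compounds, and the source may have more. Where it says the series, first, only, none or still open, it means among the compounds named here.

Of the compounds shown here, three have so far been tested in a functional assay on CCRF-CEM cells (Homo sapiens) for cytotoxicity, with a stated time of 72 h; on this read-out higher numbers stand for weaker inhibition and lower numbers for stronger inhibition. Compound 1 `C=CCOc1ccc(/C=C/C(=O)c2ccc(OCC=C(C)C)c(CC=C)c2)cc1OC` reaches only the limit of the assay, > 50000 nM. Compound 2 `C#CCOc1ccc(/C=C/C(=O)c2ccn(C)c2)cc1OC` likewise stops at a limit, > 50000 nM. Within the data shown here, compound 3 `C=CCOc1ccc(C=O)cc1OC` is the one compound with an actual number, 14000 nM. Compound 3 therefore stands alone among the values shown, as the limit of > 50000 nM in this assay, at which 2 of the 3 values shown sit, records. Compound 4 `C#CCOc1ccc(C=O)cc1OC` differs from compound 3 by ethynyl in place of vinyl on a saturated chain carbon bound to an oxygen on an aromatic ring. No step between two measured compounds is available, so nothing shown bears directly on this change, which leaves the aldehyde and the shared core untouched. The author expects a step no larger than the usual scatter, no change at the digits printed from compound 3 to compound 4 (within the scatter), and estimates compound 4 at 14000 nM, between 5000 nM and 40000 nM.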

Compound 4, half-maximal inhibitory concentration: > 50000 nM
Compound 4: a limit, no number (the forecaster's own chance of this, stated with the estimate: 25%); middle value at least 3.5-fold (0.55 log units) away from the limit.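

In this assay, propargyloxy does not stand in for allyloxy on this aldehyde: ethynyl in place of vinyl gives an at least 3.5-fold higher number from compound 3 to compound 4 (0.55 log units; beyond the scatter). Among these compounds, this is the only step between two measured compounds, and it lies beyond the scatter, so this place is sensitive to even this small change. Compound 4 reaches only a limit, so the step has a floor but no true size, and the read-out is crowded at that same limit: the limit of > 50000 nM in this assay, at which 3 of the 4 values shown sit.

From the compounds shown here alone, whether a longer chain or an amine at this place would retain the activity of compound 3 stays open. So does whether the same change would matter if a carboxylic acid replaced the aldehyde.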